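Substituent at the ring carbon flanked by two nitrogens

The source may report more compounds than this note shows. Statements on the series, on what has been measured and on what is new or still open speak of the compounds shown alone.

Going by the values given here, compound 1 `CCSc1nc(N)c2nc(O)n(Cc3ccccc3)c2n1` is the more potent of the two measured members: in a functional assay on the whole organism for activation, with Mus musculus as the target (a higher number here means that more compound is needed for the effect, a lower number that less compound is needed), compound 1 gives 0.1 mg/kg, the lowest of the two numbers, while compound 2 `Nc1ncnc2c1nc(O)n2Cc1ccccc1` gives 30 mg/kg. Among the compounds with values here, the one measured step, a 300-fold higher number from compound 1 to compound 2 (2.48 log units; beyond the scatter), shows that removing the ethylsulfanyl group from the shared core costs a great deal of activity.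

Compound 3 `CCCNc1nc(N)c2nc(O)n(Cc3ccccc3)c2n1` carries the change (propylamino in place of ethylsulfanyl on an aromatic carbon). This keeps a substituent at the same aromatic carbon rather than removing it, so the measured step bears on it only indirectly: it marks the position as sensitive, but says nothing about one group replacing another. The step is therefore expected to be far smaller than a 300-fold higher number from compound 1 to compound 2 (2.48 log units; beyond the scatter), estimated as a 3.0-fold higher number from compound 1 to compound 3 (0.48 log units; beyond the scatter), a modest loss with direction uncertain. Compound 3 is estimated at 0.3 mg/kg, with a range from 0.05 mg/kg to 3 mg/kg.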

Compound 3, minimum effective dose: 1 mg/kg
Compound 3: middle estimate off by 3.3-fold (0.52 log units), on the low side, within the range that was stated.
By their numbers in this assay, from the lowest: compound 1; then compound 3; then compound 2.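

In this assay, a substituent at this carbon need not be ethylsulfanyl for much of the activity to remain: propylamino recovers a large part of what hydrogen loses (a 30-fold lower number from compound 2 to compound 3 (1.48 log units; beyond the scatter)). The two substituents are still not equivalent, since exchanging ethylsulfanyl for propylamino carries a modest cost (a 10-fold higher number from compound 1 to compound 3 (1.00 log units; beyond the scatter)), which places compound 3 between compound 1 and compound 2. Nothing measured here accounts for the gap between ethylsulfanyl and propylamino.

This change alters the linking atom and the chain together, so the compounds shown cannot separate the two contributions. An ethylamino or a propylsulfanyl group at this carbon would separate them, while an ethoxy group would show whether a third linking atom fits the same order.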